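A few compounds are considered here, and "the series" means these few. Any claim that something is new, unique, unknown or untested is made for them only; others in the source may bear on it.

Compound 3 `O=C(O)Cc1sc(C(c2ccc(F)cc2)c2ccc(F)cc2)nc1-c1ccnc(F)c1` gives 0.48 nM in an in vitro assay on HEK385-7 cells for displacement of a labelled ligand from prostaglandin D2 receptor 2 (Homo sapiens) (on this read-out higher numbers stand for weaker inhibition and lower numbers for stronger inhibition), the lowest of the three numbers; compound 1 `O=C(O)Cc1sc(C(c2ccc(F)cc2)c2ccc(F)cc2)nc1-c1cc(F)cc(F)c1` gives 35 nM and compound 2 `NS(=O)(=O)c1ccc(-c2nc(C(c3ccc(F)cc3)c3ccc(F)cc3)sc2CC(=O)O)cc1` gives 1500 nM. The steps of a 73-fold lower number from compound 1 to compound 3 (1.86 log units; beyond the scatter) and a 3100-fold lower number from compound 2 to compound 3 (3.49 log units; beyond the scatter) were large, as was a 43-fold higher number from compound 1 to compound 2 (1.63 log units; beyond the scatter), so every measured exchange of the aromatic group on the shared core moved the number far. Compound 4 `O=C(O)Cc1sc(C(c2ccc(F)cc2)c2ccc(F)cc2)nc1-c1ccnc(O)c1` differs from compound 3 by hydroxy in place of fluoro on an aromatic carbon. Among the compounds with values here, no measured step exchanges fluoro for hydroxy on this ring, so the direction rests on inference only; given how far the measured exchanges reached, for compound 4 a moderate step toward a higher number is expected, a 6.3-fold higher number from compound 3 to compound 4 (0.80 log units; beyond the scatter). Compound 4 is therefore estimated at 3 nM, within 0.5 nM to 20 nM.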

Compound 4, half-maximal inhibitory concentration: 68 nM
Beside the measured number, compound 4's estimate is 23-fold (1.36 log units) below it; the whole stated range lies below it.
By their numbers in this assay, from the lowest: compound 3; then compounds 1 and 4 (each within the scatter of the next); then compound 2.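

On the six-membered aromatic ring with 1 nitrogen, a single exchange next to the ring nitrogen, hydroxy in place of fluoro, gives a 140-fold higher number from compound 3 to compound 4 (2.15 log units; beyond the scatter), so the low number of compound 3 depends on the fluoro and not on the ring nitrogen alone. The 2-hydroxypyridin-4-yl group shows no separation from 3,5-difluorophenyl, with a 1.9-fold higher number from compound 1 to compound 4 (0.29 log units; within the scatter), yet it still stands well clear of 4-sulfamoylphenyl, with a 22-fold lower number from compound 2 to compound 4 (1.34 log units; beyond the scatter). Nothing available explains the size of the fluoro-to-hydroxy step. As far as these compounds go, whether chloro, methoxy or an amine at this place would stay close to compound 3 or move toward compound 4 remains open.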